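The compounds below may be only part of what the source reports. "The series", "measured", "known", "first", "only" and "open" are said of these compounds alone.

Working notes on the series.

Compound 3 `COc1cc(Cl)cc(-c2nn(-c3cccc(NC(=O)Nc4ccc(Cl)c(Cl)c4)c3)cc2-c2ccncc2)c1` carries the shared core with a methoxy and a chloro on one aryl ring and a (3,4-dichlorophenyl)carbamoyl unit on the other. In a functional assay on BT-549 cells (Homo sapiens) for inhibition, read by sulforhodamine B assay, with a stated time of 48 h, tested at 1 uM (a higher number here means a weaker effect of the compound at the concentration tested, a lower number a stronger effect), compound 3 gives 92%, which is level with compound 2 `COc1cc(Cl)cc(-c2nn(-c3cccc(NC(=O)Nc4ccc(Cl)c(C(F)(F)F)c4)c3)cc2-c2ccncc2)c1` at 92%; together these are the highest of the three numbers, all pointing to a weak effect at the concentration tested. Compound 1 `O=C(Nc1cccc(-n2cc(-c3ccncc3)c(-c3cc(O)cc(Cl)c3)n2)c1)Nc1ccc(Cl)c(Cl)c1`, the free phenol, gives 89% in this assay.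

The two single-point steps measured so far are small: a number 3 percentage points higher from compound 1 to compound 3 (within the scatter) and no change at the digits printed from compound 2 to compound 3 (within the scatter), both within the scatter.

Compound 4 `COc1cc(Cl)cc(-c2nn(-c3cccc(NC(=O)c4cccc(C(F)(F)F)c4)c3)cc2-c2ccncc2)c1`, not yet measured, differs from compound 3 in one place: 3-(trifluoromethyl)phenyl in place of (3,4-dichlorophenyl)amino on a carbonyl carbon. Within the data shown here, the change removes the amide-type nitrogen that is present in every measured compound, so neither measured step bears on it directly; the closest precedent is the swap on the aromatic carbon of the same terminal ring between compound 2 and compound 3, which produced no change.

Among the measured compounds shown here, with no measured step moving the number, the working expectation is that compound 4 stays at a weak effect in this assay, estimated at 90% with a range of 72% to 102%. The expected step is a number 2 percentage points lower from compound 3 to compound 4 (within the scatter), taken as lying within the scatter.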

Compound 4, a percentage reported as activity, at one concentration (the size of the read-out at that concentration, not a potency): 94%
Estimate against measurement, compound 4: 4 percentage points below; low and high end bracket the measured number.
By their numbers in this assay, from the lowest: compounds 1, 2, 3 and 4 (each within the scatter of the next).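

Among these compounds, the carbonyl carbon tolerates a larger swap than the earlier compounds tested: where they varied only a substituent on the terminal ring or the oxygen of the phenol, this change takes out the whole (3,4-dichlorophenyl)amino group, with its nitrogen and hydrogen-bond donor, and in this assay it gives a number 2 percentage points higher from compound 3 to compound 4 (within the scatter). The same holds starting from the (4-chloro-3-(trifluoromethyl)phenyl)amino group, with a number 2 percentage points higher from compound 2 to compound 4 (within the scatter), so in these two pairs neither the nitrogen and its donor nor the choice of terminal ring separates the compounds in this read-out, and all four compounds remain close to one another at a weak effect at the concentration tested. No measurement is available that would explain this result.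

Still open, as far as these compounds go, is whether any group on this carbonyl carbon can move the number at all, for example a piperazine, a morpholine, a carboxylic acid on the terminal ring, or a longer alkyl chain in place of 3-(trifluoromethyl)phenyl. A read-out at one concentration also leaves open whether these compounds differ in potency at higher concentrations.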